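This account rests on a few compounds, and the source may have more. Where it says the series, first, only, none or still open, it means among the compounds named here.

Within the data shown here, in an ADME assay on HMEC cells (Homo sapiens) for cytotoxicity, read by MTT assay (a higher number here means a weaker inhibitor, a lower number a stronger inhibitor), three compounds have numbers so far. Compound 1 (`Nc1ccccc1NC(=O)c1ccc(CNc2nc3ccccc3[nH]2)cc1`) gives 27000 nM and compound 2 (`Nc1ccccc1NC(=O)c1ccc(CNc2nc3cc(Cl)ccc3o2)cc1`) gives 17000 nM in this test. Compound 3 (`Nc1ccccc1NC(=O)c1ccc(CSc2nc3ccc(NCc4ccccn4)cc3s2)cc1`) gives 8000 nM and so holds the lowest number of the three, with its gap to each of the other two lying beyond the usual scatter of repeat measurements.

Compound 4 (`Nc1ccccc1NC(=O)c1ccc(CSc2nc3ccc(NCc4cccnc4)cc3s2)cc1`) has yet to be measured. It has the same atoms as compound 3, joined differently (pyridin-3-yl in place of pyridin-2-yl on a saturated chain carbon bound to a nitrogen on an aromatic ring): pyridin-3-yl stands in place of pyridin-2-yl on a saturated chain carbon bound to a nitrogen on an aromatic ring.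

Among the measured compounds shown here, no two measured compounds differ in only one place, so the data hold no direct measure of a change like this one. Even so, the measured compounds, which differ in more than one place, stay fairly close, with compound 3 at 8000 nM and compound 1 at 27000 nM as the two ends. A single swap of the pyridine attachment is therefore expected to bring no step beyond the scatter in this assay, and no clear direction. The estimated step of a 1.1-fold higher number from compound 3 to compound 4 (0.05 log units; within the scatter) is accordingly small. For compound 4 the expected value is 9000 nM with an estimated range from 4500 nM to 18000 nM at its two ends.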

Compound 4, half-maximal inhibitory concentration: > 50000 nM
Compound 4 gave a limit, no number; the forecaster's own chance of this, stated with the estimate: 8%; middle value at least 5.5-fold (0.74 log units) away from the limit.
By their numbers in this assay, from the lowest: compound 3; then compounds 2 and 1 (each within the scatter of the next). At a limit, above all of these: compound 4.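

In this assay, the data now hold their first step in one place only: pyridin-3-yl in place of pyridin-2-yl on a saturated chain carbon bound to a nitrogen on an aromatic ring gives an at least 6.2-fold higher number from compound 3 to compound 4 (0.79 log units; beyond the scatter), a step beyond the scatter. Among these compounds, this position therefore responds to where the pyridine is attached, even though the leaving and entering groups have the same heavy atoms, hydrogen-bond counts and net charge, something the earlier compounds, which differ in more than one place, could not show. Compound 4 gives > 50000 nM, which is a limit and not a number, and it is the only compound shown at this limit: the limit of > 50000 nM in this assay, at which 1 of the 4 values shown sits.

The compounds shown leave open whether pyridin-4-yl or a plain phenyl ring in the same place would sit close to compound 3 or reach the same limit as compound 4. They also leave open whether a longer chain in place of the single saturated chain carbon would keep this sensitivity to the pyridine attachment, and why the swap has this effect.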